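The compounds below may be only part of what the source reports. "The series", "measured", "known", "first", "only" and "open" are said of these compounds alone.

Measured in a functional assay on HT-29 cells (Homo sapiens) for antiproliferative activity, with a stated time of 48 h; on this read-out higher numbers stand for weaker inhibition and lower numbers for stronger inhibition:
compound 1 `CCCCCc1cccc(NC(=O)NCCCCl)c1` — 28000 nM
compound 2 `CCCCC(O)c1cccc(NC(=O)NCCCCl)c1` — 19000 nM
compound 3 `CCCCCc1cccc(NC(=O)CCCCl)c1` — a limit of the assay, > 100000 nM

Compound 2 carries hydroxy in place of hydrogen on a saturated chain carbon bound to an aromatic carbon and a saturated chain carbon relative to compound 1, and this gives a 1.5-fold lower number from compound 1 to compound 2 (0.17 log units; within the scatter) in this assay. Compound 3 differs from compound 1 in the core: 3-chloropropyl in place of (3-chloropropyl)amino on a carbonyl carbon, which gives an at least 3.5-fold higher number from compound 1 to compound 3 (0.55 log units; beyond the scatter). The value for compound 3 is only a limit, (the limit of > 100000 nM in this assay, at which 1 of the 3 values shown sits).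

Compound 4 `CCCCC(O)c1cccc(NC(=O)CCCCl)c1` remains to be measured in this assay. It shares the core of compound 3 and differs from it by hydroxy in place of hydrogen on a saturated chain carbon bound to an aromatic carbon and a saturated chain carbon, the same change as that from compound 1 to compound 2, at a place described in identical words. As the change made between compound 1 and compound 2 stayed within the scatter, the step from compound 3 to compound 4 is expected to be a number no higher from compound 3 to compound 4 (the limit leaves the size open), resting on a 1.5-fold lower number from compound 1 to compound 2 (0.17 log units; within the scatter) and on compound 3 sitting at the limit of > 100000 nM in this assay, at which 1 of the 3 values shown sits. Compound 4 is therefore expected to give about 100000 nM, estimated within 50000 nM to 250000 nM, most likely reported again only as a limit.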

Compound 4, half-maximal inhibitory concentration: > 100000 nM
Compound 4 ended at the assay's limit; the forecaster's own chance of this, stated with the estimate: 70%; the middle value sits exactly at the limit.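

In this assay, 3-chloropropyl in place of (3-chloropropyl)amino on a carbonyl carbon gives an at least 5.2-fold higher number from compound 2 to compound 4 (0.72 log units; beyond the scatter), so this change raises the number on both the pentyl and the 1-hydroxypentyl compounds: the same change on two cores in this assay, an at least 3.5-fold higher number (0.55 log units; beyond the scatter) from compound 1 to compound 3 and an at least 5.2-fold higher number (0.72 log units; beyond the scatter) from compound 2 to compound 4; the limit leaves it open whether they differ

Compound 4 stands at a limit of the assay, as compound 3 does, so the step from pentyl to 1-hydroxypentyl cannot be read on this core: the limit of > 100000 nM in this assay, at which 2 of the 4 values shown sit.

The direction of the change therefore carries from one core to the other, but its size does not transfer in any readable way, and nothing shows whether the hydroxy change behaves on the core of compound 3 as it does on the core of compound 1.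

Going by these compounds, it remains open whether an amine or a carboxylic acid in place of the hydroxy on that chain carbon, or a longer chain in place of pentyl, would bring the core of compound 3 to a measurable value in this assay. On these data alone, it also remains open how far the numbers of compound 1 and compound 2 depend on the chlorine, for example with a plain propyl group in place of 3-chloropropyl.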